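The source may hold more compounds than are shown below. What is called first, only, known or untested is meant among the compounds shown, and "the series" means these compounds.

Of the compounds shown here, two have been measured so far in a functional assay on HeLa cells (Homo sapiens) for cytotoxicity, read by WST assay, with a stated time of 48 h; on this read-out higher numbers stand for weaker inhibition and lower numbers for stronger inhibition. Compound 1, whose structure is `O[C@@H](c1ccccc1)[C@H]1CO[C@H](c2ccccc2)[C@@H](C/C=C/c2cccc(F)c2)C1`, gives 8380 nM in this assay. Compound 2, with the structure `COc1ccc(/C=C/C[C@@H]2C[C@@H]([C@@H](O)c3ccc(OC)c(OC)c3)CO[C@H]2c2ccccc2)cc1OC`, gives 16100 nM in this assay. Among the compounds with values here, these two numbers lie within the usual scatter of one another, so the data do not separate compound 1 from compound 2, and compound 1 stands at a level it shares with the only other measured compound. Compound 3, with the structure `O[C@@H](c1ccccc1)[C@H]1CO[C@H](c2ccccc2)[C@@H](C/C=C/c2ccccc2F)C1`, has not yet been measured. It differs from compound 1 in a single place: 2-fluorophenyl in place of 3-fluorophenyl on a double-bonded chain carbon bound to a double-bonded chain carbon. Within the data shown here, no step between measured compounds that differ in one place is available, so there is nothing to set the size of this change against. The change exchanges one fluorophenyl group for another of the same composition, and this gives no ground for expecting a step beyond the scatter; the expected step from compound 1 to compound 3 is a 1.1-fold higher number from compound 1 to compound 3 (0.03 log units; within the scatter), in no clear direction. Compound 3 is therefore estimated at 9000 nM, within a range from 4000 nM to 20000 nM.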

Compound 3, half-maximal inhibitory concentration: 9730 nM
For compound 3 the middle estimate is 1.1-fold (0.03 log units) below the measured one; low and high end bracket the measured number.
By their numbers in this assay, from the lowest: compounds 1, 3 and 2 (each within the scatter of the next).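

Within the data shown here, at this place, on a double-bonded chain carbon bound to a double-bonded chain carbon, 2-fluorophenyl in place of 3-fluorophenyl gives in this assay a 1.2-fold higher number from compound 1 to compound 3 (0.06 log units; within the scatter) and provides the first step that can be read between compounds differing in one place. The two groups hold the same atoms and the exchange changes only how they are joined, so on this read-out the data do not separate the 2-fluorophenyl and 3-fluorophenyl forms of the shared core. Nothing measured here accounts for this result.

The compounds shown leave open how the number would respond to a plain phenyl at this place, or to a phenyl carrying a nitrile, an amine or a carboxylic acid instead of fluorine. They also leave open what a longer chain in place of the prop-2-en-1-yl link would do, and compound 2 cannot settle either question, since it differs from compound 1 in more than one place.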